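Thiourea aryl swap: bromo to phenyl at the ring nitrogen

This account rests on a few compounds, and the source may have more. Where it says the series, first, only, none or still open, it means among the compounds named here.

Compound 1 `NC(=O)c1c(NC(=O)c2ccccc2Cl)sc2c1CCN(Cc1ccc([N+](=O)[O-])cc1)C2` — 11400 nM
Compound 2 `NC(=O)c1c(NC(=O)c2ccccc2Cl)sc2c1CCN(C(=O)Nc1ccccc1Cl)C2` — 12500 nM
Compound 3 `NC(=O)c1c(NC(=O)c2ccccc2Cl)sc2c1CCN(C(=S)Nc1ccccc1Br)C2` — 9090 nM

All three share one core and differ only in the group on the amine nitrogen in the ring. In a functional assay on HL-60 cells (Homo sapiens) for antiproliferative activity, with a stated time of 24 h (a lower number here means a stronger inhibitor, a higher number a weaker inhibitor), compound 3 gives the lowest of the three numbers, yet its steps to the others, a 1.3-fold lower number from compound 1 to compound 3 (0.10 log units; within the scatter) and a 1.4-fold lower number from compound 2 to compound 3 (0.14 log units; within the scatter), both stay within the scatter, as does a 1.1-fold higher number from compound 1 to compound 2 (0.04 log units; within the scatter). So far, changing this group has not moved the numbers by more than the usual spread.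

Compound 4 `NC(=O)c1c(NC(=O)c2ccccc2Cl)sc2c1CCN(C(=S)Nc1ccccc1-c1ccccc1)C2` keeps the thiourea of compound 3 and changes only its aryl ring: phenyl in place of bromo on an aromatic carbon, that is, 2-bromophenyl becomes 2-phenylphenyl. Among the compounds with values here, no measured step tests this particular change; the measured steps only show that swaps on the ring nitrogen gave steps within the scatter. On that basis compound 4 is expected to show no step beyond the scatter, a 1.0-fold higher number from compound 3 to compound 4 (0.02 log units; within the scatter). The estimate for compound 4 is 9500 nM, with a range from 3000 nM to 30000 nM.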

Compound 4, half-maximal inhibitory concentration: 34400 nM
Compound 4: the middle estimate sits 3.6-fold (0.56 log units) below what was measured; the measured number lies above the stated range.
By their numbers in this assay, from the lowest: compounds 3, 1 and 2 (each within the scatter of the next); then compound 4.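

In this assay the swap of bromo for phenyl gives a 3.8-fold higher number from compound 3 to compound 4 (0.58 log units; beyond the scatter) and this is the first step among these compounds that lies beyond the scatter, though a modest one. It shows that the aryl ring of the thiourea does not accept every group equally: 2-phenylphenyl gives a weaker inhibitor than 2-bromophenyl, whereas the swaps among compounds 1, 2 and 3 stayed within the scatter. Nothing available here explains why this change raises the number.

Still open, from the compounds shown here alone, is whether a methyl group or a plain hydrogen on this aromatic carbon would keep the number close to that of compound 3. Also open, going by these compounds, is whether an amine or a carboxylic acid on the added phenyl ring would alter the outcome of this swap.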